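This account rests on a few compounds, and the source may have more. Where it says the series, first, only, none or still open, it means among the compounds named here.

Measured so far in a functional assay on MCF7 cells (Homo sapiens) for cytotoxicity, read by CellTiter-Glo, with a stated time of 5 days; on this read-out lower numbers stand for stronger inhibition and higher numbers for weaker inhibition:
- Compound 1 `CC/C(=C(\c1ccc2[nH]ncc2c1)c1ccc(/C=C/C(=O)O)cc1C)c1ccccc1` gives 36 nM
- Compound 2 `CC/C(=C(/c1ccc(/C=C/C(=O)O)cc1)c1ccc2[nH]ncc2c1)c1ccc(Cl)cc1` gives 15 nM

Of these two numbers, compound 2 has the lower one, so it shows the stronger inhibition, and its gap to compound 1 lies beyond the usual scatter of repeat measurements. The next compound to be tested, compound 3 `CC/C(=C(/c1ccc(/C=C/C(=O)O)cc1)c1ccc2[nH]ncc2c1)c1ccc(C#N)cc1Cl`, is built from compound 2 by a single change: 2-chloro-4-cyanophenyl stands in place of 4-chlorophenyl on a double-bonded chain carbon bound to a double-bonded chain carbon and a saturated chain carbon (2-chloro-4-cyanophenyl in place of 4-chlorophenyl on a double-bonded chain carbon bound to a double-bonded chain carbon and a saturated chain carbon). Among the compounds with values here, compounds 1 and 2 differ in more than one place, so no measured pair shows what a single change does in this set. The best anchor is therefore compound 2 at 15 nM itself, and only a small shift is expected. The estimated change is a 1.3-fold higher number from compound 2 to compound 3 (0.12 log units; within the scatter), a slightly higher number that is expected to stay within the scatter. For compound 3 the expected value in this assay is 20 nM, with an estimated range from 6 nM to 60 nM at either end.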

Compound 3, half-maximal inhibitory concentration: 4 nM
The estimate for compound 3 lay 5.0-fold (0.70 log units) above the measured number, and the stated range ends above it.
By their numbers in this assay, from the lowest: compound 3; then compound 2; then compound 1.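

In this assay, within the data shown here, the new group gives a 3.8-fold lower number from compound 2 to compound 3 (0.57 log units; beyond the scatter), and this is the first single change in the set whose size can be read. It shows that this position accepts a ring carrying both a chlorine and a nitrile, and that the larger group, with its hydrogen-bond acceptor, comes with a lower number rather than a higher one. Nothing measured here speaks to the reason for this step.

From the compounds shown here alone, the change also does more than one thing at once, as the chlorine of 2-chloro-4-cyanophenyl does not stand where the name 4-chlorophenyl puts it and a nitrile enters as well, so the share of each in the step stays open. Whether 4-cyanophenyl or 2-chlorophenyl alone would give a number like that of compound 3, or whether 2-chloro-4-fluorophenyl would keep the gain without the nitrile, remains an open question.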